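Removing One Methoxy From the Carbonyl-Side Aryl

The source may hold more compounds than are shown below. What is called first, only, known or untested is meant among the compounds shown, and "the series" means these compounds.

Compound 3 `COc1ccc(C(=O)/C=C/c2cc(-c3cc(OC)c(OC)c(OC)c3)n[nH]2)cc1OC` stands second highest of the three numbers in a functional assay on Malme-3M cells (Homo sapiens) for cytotoxicity, read by sulforhodamine B assay, with a stated time of 48 h, tested at 0.01 uM (on this read-out lower numbers stand for a stronger effect and higher numbers for a weaker effect at the one concentration tested), where compound 3 gives 95%. Its nearest neighbour is compound 2 `COc1cc(-c2cc(/C=C/C(=O)c3ccc(Cl)c(Cl)c3)[nH]n2)cc(OC)c1OC`, which in this assay gives 94%; the step between them is a number 1 percentage points higher from compound 2 to compound 3 (within the scatter). The furthest is compound 1 `COc1cc(-c2cc(/C=C/C(=O)c3ccc(N)cc3)[nH]n2)cc(OC)c1OC`, which in this assay gives 98%; that step is a number 3 percentage points lower from compound 1 to compound 3 (within the scatter), and between the other two it is a number 4 percentage points lower from compound 1 to compound 2 (within the scatter).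

Compound 4 `COc1ccc(C(=O)/C=C/c2cc(-c3cc(OC)c(OC)c(OC)c3)n[nH]2)cc1` differs from compound 3 by hydrogen in place of methoxy on an aromatic carbon. Among the measured compounds shown here, every measured step so far alters the aryl group on a carbonyl carbon, as this change does, and all three stayed within the scatter. For the measured compounds named here, no measured pair shows the exact move from 3,4-dimethoxyphenyl to 4-methoxyphenyl. On this basis a step no larger than the scatter is expected, with no particular direction, so for compound 4 the expected step is no change at the digits printed from compound 3 to compound 4 (within the scatter). The estimate for compound 4 in this assay is 95%, ranging from 85% to 101%.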

Compound 4, a percentage reported as activity, at one concentration (the size of the read-out at that concentration, not a potency): 95%
The estimate for compound 4 equals the measured number at the digits printed; low and high end bracket the measured number.
By their numbers in this assay, from the lowest: compounds 2, 3, 4 and 1 (each within the scatter of the next).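

In this assay, among the compounds shown here, the step of no change at the digits printed from compound 3 to compound 4 (within the scatter) is the first direct reading of hydrogen in place of methoxy on this aromatic carbon, ortho to a methoxy group, and the 3,4-dimethoxyphenyl to 4-methoxyphenyl change leaves the read-out unmoved at this concentration. The 4-methoxyphenyl group also joins the other aryl groups on the carbonyl carbon without separating from them, with a number 1 percentage points higher from compound 2 to compound 4 (within the scatter) and a number 3 percentage points lower from compound 1 to compound 4 (within the scatter), so no aryl group shown stands apart. No evidence is available that bears on this result.

With a single low concentration, the compounds shown leave open whether this methoxy matters at concentrations where the cells respond more strongly. They also leave open how a hydroxy, an ethoxy or a fluorine on this aromatic carbon would read.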